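This account rests on a few compounds, and the source may have more. Where it says the series, first, only, none or still open, it means among the compounds named here.

The compounds share one core, carrying a trifluoromethyl group and a side chain joined through an oxygen. Compound 1 `CCOC(=O)C1=Cc2ccccc2OC1(OCc1cc(-c2ccc(OC)cc2)no1)C(F)(F)F` is an ethyl ester; in a functional assay on MCF7 cells (Homo sapiens) for inhibition, read by MTT assay, with a stated time of 24 h (a higher number here means a weaker inhibitor, a lower number a stronger inhibitor), compound 1 reaches only the limit > 150000 nM. Compound 3 `COc1ccc(-c2cc(COC3(C(F)(F)F)Oc4ccccc4C=C3C(=O)O)on2)cc1` is the matching acid, and in this assay compound 3 gives 35200 nM. That change, hydrogen in place of ethyl on an oxygen next to a carbonyl group, gives an at least 4.2-fold lower number from compound 1 to compound 3 (0.62 log units; beyond the scatter). Compound 2 `CCOC(=O)C1=Cc2ccccc2OC1(OCc1cn(CC(=O)Nc2ccc(C)cc2)nn1)C(F)(F)F` keeps the ethyl ester but carries a different side chain ending in an amide. In this assay compound 2 also stops at the limit > 150000 nM. This matches (the limit of > 150000 nM in this assay, at which 2 of the 3 values shown sit). Compound 4 `CCOC(=O)C1=Cc2ccccc2OC1(OCc1cn(CC(=O)Nc2ccc(I)cc2Cl)nn1)C(F)(F)F` has not been measured. It differs from compound 2 only on an amide-type nitrogen: 2-chloro-4-iodophenyl in place of 4-methylphenyl on an amide-type nitrogen. Within the data shown here, no measured step touches this position; the single measured step, from compound 1 to compound 3, changes the ester group and tells nothing about the group on the amide-type nitrogen. Compound 2 sits at a limit, which leaves little room to see a change. The expected step is a step that the limit leaves unreadable from compound 2 to compound 4, staying within the scatter. Compound 4 is therefore estimated at 200000 nM, with a range from 70000 nM to 600000 nM, and a real chance that this assay again reports only a limit.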

Compound 4, half-maximal inhibitory concentration: 28100 nM
For compound 4 the middle estimate is 7.1-fold (0.85 log units) above the measured one; measured number outside the range, below it.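

This position on the amide-type nitrogen, untouched by the earlier step, turns out to matter: in this assay, 2-chloro-4-iodophenyl in place of 4-methylphenyl gives an at least 5.3-fold lower number from compound 2 to compound 4 (0.72 log units; beyond the scatter). Compound 4 still carries the ethyl ester, so among the compounds shown, an ethyl ester does not always go with a reading at the limit, and the earlier change of ester to acid is not the only change seen to lower the number. The true size of the new step stays unknown, and only its minimum can be read, because the starting point, compound 2, is a limit and not a number: the limit of > 150000 nM in this assay, at which 2 of the 4 values shown sit.

The step swaps the methyl group for iodine and also adds a chlorine, so the compounds shown do not tell which of the two carries the change; a 4-iodophenyl or a 2-chlorophenyl group on the same nitrogen would separate them. They also leave open how a carboxylic acid in place of the ethyl ester would read with this side chain, given the earlier result of an at least 4.2-fold lower number from compound 1 to compound 3 (0.62 log units; beyond the scatter).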